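The source may report more compounds than this note shows. Statements on the series, on what has been measured and on what is new or still open speak of the compounds shown alone.

Compound 1 `CC(C)(C)OC(=O)N1CCC[C@H]1C(=O)N1CCC(NS(=O)(=O)c2cc(S(=O)(=O)c3ccccc3)ccc2C(F)(F)F)CC1` is the starting point of this set. Among the measured compounds shown here, in a functional assay on U2OS cells for antagonist activity at proto-oncogene Wnt-3 (Homo sapiens), read by a luciferase reporter, with a stated time of 18 h (on this read-out higher numbers stand for an effect only at larger amounts of compound and lower numbers for an effect already at smaller amounts), compound 1 gives 60 nM, the lowest of the three numbers measured so far. Compound 2 `CC(C)(C)C(=O)N1CCC[C@H]1C(=O)N1CCC(NS(=O)(=O)c2cc(S(=O)(=O)c3ccccc3)ccc2C(F)(F)F)CC1` gives 270 nM in this assay, and a 4.5-fold higher number from compound 1 to compound 2 (0.65 log units; beyond the scatter). Compound 3 `CN(C)c1ccc(C(=O)N2CCC[C@H]2C(=O)N2CCC(NS(=O)(=O)c3cc(S(=O)(=O)c4ccccc4)ccc3C(F)(F)F)CC2)cc1` gives 830 nM in this assay, and a 14-fold higher number from compound 1 to compound 3 (1.14 log units; beyond the scatter); between the two larger numbers, a 3.1-fold higher number from compound 2 to compound 3 (0.49 log units; beyond the scatter). Every change made so far at the carbonyl carbon whose other neighbour is the amide-type nitrogen in a ring has moved the number upward and beyond the scatter.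

Compound 4 `CC(C)(C)NC(=O)N1CCC[C@H]1C(=O)N1CCC(NS(=O)(=O)c2cc(S(=O)(=O)c3ccccc3)ccc2C(F)(F)F)CC1` is not yet measured. It differs from compound 1 by (tert-butyl)amino in place of tert-butoxy on a carbonyl carbon. For the measured compounds named here, the steps that bear on it are those from compound 1 to compound 2 and from compound 1 to compound 3, since both also replace tert-butoxy on that carbonyl carbon; both raised the number, the first modestly and the second by a large amount. The entering (tert-butyl)amino keeps the same count of heavy atoms as tert-butyl, so the step from compound 1 to compound 2 is the closer guide. A modest rise is therefore expected, a 2.5-fold higher number from compound 1 to compound 4 (0.40 log units; beyond the scatter). Compound 4 is estimated at 150 nM in this assay, with a likely range from 50 nM to 450 nM.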

Compound 4, half-maximal effective concentration: 30 nM
Estimate against measurement, compound 4: 5.0-fold (0.70 log units) above; measured number outside the range, below it.
By their numbers in this assay, from the lowest: compounds 4 and 1 (each within the scatter of the next); then compound 2; then compound 3.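

In this assay, among the compounds shown here, (tert-butyl)amino in place of tert-butoxy on the carbonyl carbon is the first change at this position that stays within the scatter, with a 2.0-fold lower number from compound 1 to compound 4 (0.30 log units; within the scatter), so exchanging the oxygen for nitrogen, and an acceptor for a donor, gives no readable change. The other two steps show that the tert-butyl group alone does not set the number: a 9.0-fold lower number from compound 2 to compound 4 (0.95 log units; beyond the scatter), and the gap to the aryl amide is wider still, with a 28-fold lower number from compound 3 to compound 4 (1.44 log units; beyond the scatter), so among these compounds the two groups joined to the carbonyl through oxygen or nitrogen lie low, while the two joined through carbon, in compound 2 and compound 3, lie higher. No measurement in hand accounts for the gap between the linked and directly attached groups.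

The compounds shown leave open whether the amide hydrogen of compound 4 matters, which a (tert-butyl)(methyl)amino group on the same carbonyl carbon would test. They also leave open how far the bulk on the nitrogen can shrink, as with a methylamino or an isopropylamino group.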